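The source may report more compounds than this note shows. Statements on the series, on what has been measured and on what is new or still open speak of the compounds shown alone.

Measured compounds:
Compound 1, `COc1cc([C@H]2Oc3cc(O)ccc3C(=O)[C@@H]2O)ccc1O`. In a functional assay on U-937 cells (Homo sapiens) for antiproliferative activity, read by WST assay, with a stated time of 24 h (a lower number here means a stronger inhibitor, a higher number a weaker inhibitor), compound 1 reaches only the limit of the measurement, > 100000 nM.
Compound 2, `COc1ccc([C@@H]2CCc3c(OC)cc(OC)cc3O2)cc1`. In this assay compound 2 gives 29000 nM.
Compound 3, `COc1ccc([C@@H]2CCc3c(OC)cc(OC)cc3O2)c(OC)c1`. In this assay compound 3 also reaches only the limit, > 100000 nM.

Compound 3 thus stands at the weak edge of what this assay can report: its value is a limit, not a number, and it shares that position with compound 1, as noted in the limit of > 100000 nM in this assay, at which 2 of the 3 values shown sit. Going by the values given here, the one measured step that reaches compound 3 is an at least 3.4-fold higher number from compound 2 to compound 3 (0.53 log units; beyond the scatter), so adding a methoxy group to an aromatic carbon pushed the compound from a measurable, though weak, number out to the limit.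

Compound 4, `COc1ccc([C@@H]2CCc3c(OC)cc(OC)cc3O2)c(O)c1`, differs from compound 3 in a single place: hydrogen in place of methyl on an oxygen on an aromatic ring. Among the compounds with values here, no measured step shows what trading a methoxy for a hydroxy does here, so the only guide is that compound 3 sits at the limit while compound 2, lacking the group altogether, gives a number. The expectation is therefore a compound that remains weak in this assay, with a fair chance that only a limit is reported again; the expected step is an at least 1.2-fold lower number from compound 3 to compound 4 (0.09 log units; that floor lies within the scatter). Compound 4 is estimated at 80000 nM, within a range from 30000 nM to 300000 nM.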

Compound 4, half-maximal inhibitory concentration: 37000 nM
Estimate against measurement, compound 4: 2.2-fold (0.33 log units) above; measured number inside the range.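

In this assay, hydroxy in place of methoxy on this aromatic carbon brings back a measurable number, with an at least 2.7-fold lower number from compound 3 to compound 4 (0.43 log units; beyond the scatter). Set against the compound with only hydrogen on that carbon, the hydroxy gives no change that can be told apart, with a 1.3-fold higher number from compound 2 to compound 4 (0.11 log units; within the scatter); among these compounds, then, the methoxy at this position goes with the loss of a measurable number, while the hydroxy does not. The size of the first step is only a floor because the value of compound 3 is a limit and not a number: the limit of > 100000 nM in this assay, at which 2 of the 4 values shown sit.

Compound 2 and compound 4 both remain weak inhibitors in this assay, so these compounds do not show whether any group on this carbon can give a lower number than hydrogen or hydroxy does. Going by these compounds, whether an amine, a fluorine atom or a longer ether chain at this position would follow the hydroxy or the methoxy stays open, as does whether the same swap of methoxy for hydroxy would give a similar result elsewhere on the shared core.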